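The compounds below may be only part of what the source reports. "The series", "measured", "known", "first", "only" and "open" are said of these compounds alone.

Measured so far in an ADME assay on HT-29 cells (Homo sapiens) for cytotoxicity, read by MTT assay, with a stated time of 72 h; on this read-out higher numbers stand for weaker inhibition and lower numbers for stronger inhibition:
- compound 1 `COc1ccc(C2=C(c3cc(OC)c(OC)c(OC)c3)C(=O)CC2O[SiH2]C(C)(C)C)cc1`: > 100 ug/mL (a limit)
- compound 2 `COc1cc(C2=C(c3ccc(SC)cc3)CC(O[SiH2]C(C)(C)C)C2=O)cc(OC)c1OC`: < 1 ug/mL (a limit)
- compound 3 `COc1ccc(C2=C(c3cc(OC)c(OC)c(OC)c3)C(=O)CC2O)cc1`: 15 ug/mL

Compound 1 sits at the limit of > 100 ug/mL in this assay, at which 1 of the 3 values shown sits, so its value is a limit and not a number. Compound 2 also gives a limit, at the other end of the range, (the limit of < 1 ug/mL in this assay, at which 1 of the 3 values shown sits). Going by the values given here, compound 3 gives a true number, and the one measured step is an at least 6.6-fold lower number from compound 1 to compound 3 (0.82 log units; beyond the scatter).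

Compound 4 `COc1cc(C2=C(c3cc(C)c(OC)c(C)c3)C(O[SiH2]C(C)(C)C)CC2=O)cc(OC)c1OC` changes compound 1 in a single place: 4-methoxy-3,5-dimethylphenyl in place of 4-methoxyphenyl on a double-bonded ring carbon. In words, 4-methoxy-3,5-dimethylphenyl stands in place of 4-methoxyphenyl on a double-bonded ring carbon. The measured step does not cover this change. It concerns a different place, which compound 4 leaves as it is in compound 1. Among the compounds with values here, no measured step shows what this exchange of groups does in this assay.

The expectation therefore rests on compound 1 alone, whose > 100 ug/mL is a limit. No shift beyond the scatter is expected in either direction, and the expected step is a number no higher from compound 1 to compound 4 (the limit leaves the size open). A report of only a limit would be no surprise. For compound 4 the estimated value is 100 ug/mL, with an expected range from 20 ug/mL to 200 ug/mL.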

Compound 4, half-maximal inhibitory concentration: 10 ug/mL
For compound 4 the middle estimate is 10-fold (1.00 log units) above the measured one, and the stated range ends above it.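

In this assay, putting 4-methoxy-3,5-dimethylphenyl in place of 4-methoxyphenyl on a double-bonded ring carbon gives an at least 10-fold lower number from compound 1 to compound 4 (1.00 log units; beyond the scatter), which shows that this position, untouched by the earlier step, responds to the group it carries. The earlier step, an at least 6.6-fold lower number from compound 1 to compound 3 (0.82 log units; beyond the scatter), lies at a different place, so two separate places on the core of compound 1 can now each lower the number beyond the scatter. The value of compound 1 is a limit and not a number, so the new step fixes only a smallest size and leaves the true size open: the limit of > 100 ug/mL in this assay, at which 1 of the 4 values shown sits.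

The compounds shown do not tell why the number falls, whether the methyl groups of the entering ring matter on their own or together, or how an amine or a carboxylic acid on that ring would behave at this carbon. Going by these compounds, it also remains open whether the same exchange would lower the number of compound 3, which gives 15 ug/mL and carries a free hydroxyl group where compound 1 carries its silicon-bearing group.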